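The compounds below may be only part of what the source reports. "The series", "measured", "known", "first", "only" and "open" are said of these compounds alone.

Measured so far in a physicochemical assay for solubility, read by turbidimetry, measured as kinetic solubility, at pH 7.4; a higher number here means a more soluble compound, a lower number a less soluble compound: compound 1 `CC1SC(c2cccc(C(=O)NCCCCc3ccccc3)c2)N(c2ccc(C3CC3)cc2)C1=O` gives 2000 nM; compound 2 `COc1ccccc1N1C(=O)C(C)SC1c1cccc(C(=O)NCCCCc2ccccc2)c1` gives 10000 nM; compound 3 `COc1ccc(F)cc1N1C(=O)CSC1c1cccc(C(=O)NCCCCn2cccn2)c1` gives 50000 nM.

Compound 3 stands highest of the three, with compound 2 nearer to it and compound 1 furthest away. Compound 4 `O=C(NCCCCn1cccn1)c1cccc(C2SCC(=O)N2c2ccccn2)c1` is not yet measured; it differs from compound 3 in one place: pyridin-2-yl in place of 5-fluoro-2-methoxyphenyl on an amide-type nitrogen in a ring. Within the data shown here, the only measured step at this position is a 5.0-fold higher number from compound 1 to compound 2 (0.70 log units; beyond the scatter), a modest rise that swaps different groups there, so it bears on compound 4 only indirectly. Among the measured compounds shown here, no measured step brings a pyridin-2-yl in, so a step of no more than modest size is expected, in an uncertain direction. Compound 4 is expected at 60000 nM, within 20000 nM to 150000 nM, which means an estimated step of a 1.2-fold higher number from compound 3 to compound 4 (0.08 log units; within the scatter).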

Compound 4, solubility: 50000 nM
The estimate for compound 4 lay 1.2-fold (0.08 log units) above the measured number; the range from low to high includes it.
By their numbers in this assay, from the lowest: compound 1; then compound 2; then compounds 3 and 4 (each within the scatter of the next).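

In this assay, pyridin-2-yl in place of 5-fluoro-2-methoxyphenyl gives no change at the digits printed from compound 3 to compound 4 (within the scatter). The earlier step at this position, a 5.0-fold higher number from compound 1 to compound 2 (0.70 log units; beyond the scatter), exchanged one carbon-only aromatic ring for another, whereas this one shows that a ring with a hetero atom can stand here with the number held level. Nothing available explains this result. Still open, as far as these compounds go, is whether a carboxylic acid or an amine on this ring would move the number. Also open, from the compounds shown here alone, is whether pyridin-2-yl would give the same result with the side chain of compound 2.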